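The source may hold more compounds than are shown below. What is called first, only, known or untested is meant among the compounds shown, and "the series" means these compounds.

Compound 1 `Cc1cc(C)cc(S(=O)(=O)c2c(C(=O)NCc3ccc(F)cc3)[nH]c3ccc(Cl)cc23)c1` and compound 2 `Cc1cc(C)cc(S(=O)(=O)c2c(C(=O)NCc3ccccc3[N+](=O)[O-])[nH]c3ccc(Cl)cc23)c1` share one core and differ only in the aromatic group on a saturated chain carbon bound to an amide-type nitrogen. In an ADME assay on MT4 cells (Homo sapiens) for cytotoxicity, read by MTT assay (on this read-out higher numbers stand for lower toxicity in this test and lower numbers for higher toxicity in this test), compound 1 gives > 53000 nM, which is a limit of the assay and not a number. Compound 2 gives > 50200 nM, and this too is only a limit, so compound 2 has no exact position on the scale. Compound 3 `Cc1cc(C)cc(S(=O)(=O)c2c(C(=O)NCc3ccc(N(C)C)cc3)[nH]c3ccc(Cl)cc23)c1` has 4-(dimethylamino)phenyl in place of 2-nitrophenyl at that same place: 4-(dimethylamino)phenyl in place of 2-nitrophenyl on a saturated chain carbon bound to an amide-type nitrogen. Within the data shown here, the one measured step at this place is a step that the two limits leave unreadable from compound 1 to compound 2, and it offers no size to carry forward. On that thin basis, the expected change is an at least 1.1-fold lower number from compound 2 to compound 3 (0.04 log units; that floor lies within the scatter), which means no clear step beyond the scatter in either direction. In this assay, the estimate for compound 3 is 45000 nM, with the result expected between 18000 nM and 60000 nM.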

Compound 3, half-maximal cytotoxic concentration: 40700 nM
Compound 3: the middle estimate sits 1.1-fold (0.04 log units) above what was measured, and the stated range covers the measured number.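

Among these compounds, compound 3 gives the first exact number at this place in this assay, and 4-(dimethylamino)phenyl in place of 2-nitrophenyl comes out as an at least 1.2-fold lower number from compound 2 to compound 3 (0.09 log units; that floor lies within the scatter). Dimethylamino in place of fluoro on an aromatic carbon reads as an at least 1.3-fold lower number from compound 1 to compound 3 (0.11 log units; that floor lies within the scatter), and this floor rests on the limit set by compound 1: the limit of > 53000 nM in this assay, at which 1 of the 3 values shown sits. The other floor stays a floor because compound 2 also gives only a limit: the limit of > 50200 nM in this assay, at which 1 of the 3 values shown sits.

From the compounds shown here alone, the true size of both steps stays open, and the step from compound 1 to compound 2 cannot be read at all. Also open, going by these compounds, is how the number in this assay would respond to a carboxylic acid or a simple aliphatic amine on a saturated chain carbon bound to an amide-type nitrogen.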